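A Longer Linker to the Fluorophenyl End

This account rests on a few compounds, and the source may have more. Where it says the series, first, only, none or still open, it means among the compounds named here.

Compound 1 `COc1cc(NC(C)CCCNC(=O)Nc2cccc(F)c2)c2ncccc2c1` is examined in a functional assay on L1210 cells (Mus musculus) for inhibition, read by MTT assay, with a stated time of 72 h (a lower number here means a stronger inhibitor, a higher number a weaker inhibitor), where compound 1 gives 19000 nM. Among the three compounds measured so far this is the highest number, yet the others sit close by: compound 2 `COc1cc(NC(C)CCCNC(=O)Nc2cccc(Cl)c2)c2ncccc2c1` gives 17000 nM and compound 3 `COc1cc(NC(C)CCCNC(=O)NNC(=O)Nc2ccc(C(F)(F)F)cc2)c2ncccc2c1` gives 18000 nM, and both lie within the scatter of the value of compound 1. Among the measured compounds shown here, the only step defined between measured compounds, a 1.1-fold lower number from compound 1 to compound 2 (0.05 log units; within the scatter), is likewise within the scatter.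

Compound 4 `COc1cc(NC(C)CCCNC(=O)NNC(=O)Nc2cccc(F)c2)c2ncccc2c1` has not yet been measured. It differs from compound 1 in one place: ((3-fluorophenyl)carbamoyl)amino in place of 3-fluorophenyl on an amide-type nitrogen. For the measured compounds named here, no measured step reproduces this change directly. The nearest reference point is compound 3, which carries the same kind of extension on the amide-type nitrogen but ends in a differently substituted phenyl, and the value of compound 3, 18000 nM, is within the scatter of the value of compound 1, 19000 nM. On that basis the observer expects the step of a 1.1-fold lower number from compound 1 to compound 4 (0.02 log units; within the scatter) to remain within the scatter, with no clear direction. Compound 4 is therefore estimated at 18000 nM, with a range from 9000 nM to 40000 nM.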

Compound 4, half-maximal inhibitory concentration: 108000 nM
Compound 4: the middle estimate sits 6.0-fold (0.78 log units) below what was measured; measured number above the stated range.
By their numbers in this assay, from the lowest: compounds 2, 3 and 1 (each within the scatter of the next); then compound 4.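

In this assay, the amide-type nitrogen proves sensitive to this change: ((3-fluorophenyl)carbamoyl)amino in place of 3-fluorophenyl gives a 5.7-fold higher number from compound 1 to compound 4 (0.75 log units; beyond the scatter), and ((3-fluorophenyl)carbamoyl)amino in place of 3-chlorophenyl gives a 6.4-fold higher number from compound 2 to compound 4 (0.80 log units; beyond the scatter). Among the compounds shown here, these are the first steps to pass beyond the scatter, whereas chloro in place of fluoro gave only a 1.1-fold lower number from compound 1 to compound 2 (0.05 log units; within the scatter), which lies within it. With the extension kept, the aromatic end also counts, since 3-fluorophenyl in place of 4-(trifluoromethyl)phenyl gives a 6.0-fold higher number from compound 3 to compound 4 (0.78 log units; beyond the scatter), and nothing presented here accounts for these rises.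

The compounds shown leave open whether the gap between compound 3 and compound 4 follows the identity of the ring substituent or where it sits, since the two end groups differ in both; a 4-fluorophenyl or a 3-(trifluoromethyl)phenyl end would separate the two. They also leave open whether the extended chain would tolerate an unsubstituted phenyl or a ring carrying an amine or a carboxylic acid.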